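The compounds below may be only part of what the source reports. "The series", "measured", "known", "first", "only" and "open" are said of these compounds alone.

Compound 1 `COC(=O)[C@@H](C)NC(=O)Cn1cc(C2=C(c3c[nH]c4ccccc34)C(=O)N(C)C2=O)c2ccccc21`: 15800 nM
Compound 2 `COC(=O)CC[C@@H](NC(=O)Cn1cc(C2=C(c3c[nH]c4ccccc34)C(=O)N(C)C2=O)c2ccccc21)C(=O)OC`: 32300 nM

Both compounds were tested in a functional assay on A2780 cells (Homo sapiens) for cytotoxicity, read by MTT assay, with a stated time of 24 h; a higher number here means a weaker inhibitor, a lower number a stronger inhibitor. Of the two, compound 2 has the higher number, 32300 nM, so it is the weaker inhibitor here.

The next compound is compound 3 `COC(=O)C[C@@H](NC(=O)Cn1cc(C2=C(c3c[nH]c4ccccc34)C(=O)N(C)C2=O)c2ccccc21)C(=O)OC`, which is yet to be measured. It differs from compound 2 in one group: methoxycarbonyl in place of (methoxycarbonyl)methyl on a saturated chain carbon, two bonds along the chain from an amide-type nitrogen and a carbonyl carbon. In words, methoxycarbonyl stands in place of (methoxycarbonyl)methyl on a saturated chain carbon, two bonds along the chain from an amide-type nitrogen and a carbonyl carbon.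

Among the measured compounds shown here, only one measured step bears on this change. At that same carbon, (methoxycarbonyl)methyl replaced hydrogen in a 2.0-fold higher number from compound 1 to compound 2 (0.31 log units; beyond the scatter), a modest step that lies just beyond the scatter. Compound 3 keeps a group at that carbon, so it is expected to move only part of the way back along that step. For the measured compounds named here, one step is thin evidence, and no measured compound yet carries methoxycarbonyl there.

In this assay, the expected change is a 1.3-fold lower number from compound 2 to compound 3 (0.13 log units; within the scatter), a small move to a lower number that probably stays within the scatter. For compound 3 the estimate is 24000 nM, with an expected range of 11000 nM to 52000 nM.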

Compound 3, half-maximal inhibitory concentration: 15400 nM
The estimate for compound 3 lay 1.6-fold (0.19 log units) above the measured number; the measured number falls inside the stated range.
By their numbers in this assay, from the lowest: compounds 3 and 1 (each within the scatter of the next); then compound 2.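

The earlier step could be read as saying that any ester-bearing group at this carbon raises the number, and this result corrects that reading. In this assay, methoxycarbonyl in place of (methoxycarbonyl)methyl gives a 2.1-fold lower number from compound 2 to compound 3 (0.32 log units; beyond the scatter), a modest step just beyond the scatter, so a difference of one heavy atom in this group is enough to shift the result. Methoxycarbonyl in place of hydrogen at the same carbon gives a 1.0-fold lower number from compound 1 to compound 3 (0.01 log units; within the scatter), which means the two compounds cannot be told apart here, so among these three compounds only the one carrying (methoxycarbonyl)methyl stands apart, and nothing available explains why this group differs from the other two.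

On these data alone, it remains open whether a carboxylic acid or an amine at this carbon would track with hydrogen and methoxycarbonyl or with (methoxycarbonyl)methyl. A longer chain ending in the same ester is also untested among the compounds shown, so three compounds in this assay cannot say whether the number keeps rising as the chain grows.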